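Aryl swap on the shared core: compound 3 to compound 4

The compounds below may be only part of what the source reports. "The series", "measured", "known", "first", "only" and "open" are said of these compounds alone.

Within the data shown here, compound 3 `C=C(Br)C(=O)Nc1cccc(-c2cn3nc(-c4cccs4)sc3n2)c1` gives 170 nM in a functional assay on L1210 cells (Mus musculus) for inhibition, read by cell counting, with a stated time of 2 days (on this read-out higher numbers stand for weaker inhibition and lower numbers for stronger inhibition), and holds the lowest number of the three measured so far. Compound 1 `C=C(Br)C(=O)Nc1cccc(-c2cn3nc(-c4ccc(C)cc4)sc3n2)c1` gives 920 nM in this assay, and compound 2 `C=C(Br)C(=O)Nc1cccc(-c2cn3nc(-c4cccc(OC)c4)sc3n2)c1` gives 580 nM. The step of a 1.6-fold lower number from compound 1 to compound 2 (0.20 log units; within the scatter) stays within the scatter, whereas a 5.4-fold lower number from compound 1 to compound 3 (0.73 log units; beyond the scatter) and a 3.4-fold lower number from compound 2 to compound 3 (0.53 log units; beyond the scatter) both lie beyond it, so compound 3 with its thiophen-2-yl stands apart from the two analogs carrying a six-membered aromatic ring of carbon only.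

Compound 4 `C=C(Br)C(=O)Nc1cccc(-c2cn3nc(-c4ccc(Cl)cc4)sc3n2)c1` carries the change (4-chlorophenyl in place of thiophen-2-yl on an aromatic carbon). The step bearing most directly on it is the reverse of a 5.4-fold lower number from compound 1 to compound 3 (0.73 log units; beyond the scatter), since 4-chlorophenyl and 4-methylphenyl are both a six-membered aromatic ring of carbon only with one group on it; a 3.4-fold lower number from compound 2 to compound 3 (0.53 log units; beyond the scatter) points the same way. Both measured six-membered aryl analogs gave higher numbers than compound 3, so a modest rise in this assay is expected on going to compound 4, landing near the span of compound 1 and compound 2. The estimated step is a 4.1-fold higher number from compound 3 to compound 4 (0.61 log units; beyond the scatter). Compound 4 is expected to give 700 nM in this assay, with a range from 250 nM to 2000 nM.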

Compound 4, half-maximal inhibitory concentration: 1400 nM
For compound 4 the middle estimate is 2.0-fold (0.30 log units) below the measured one; the measured number falls inside the stated range.
By their numbers in this assay, from the lowest: compound 3; then compounds 2, 1 and 4 (each within the scatter of the next, the first and the last beyond it).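

In this assay, 4-chlorophenyl in place of thiophen-2-yl gives an 8.2-fold higher number from compound 3 to compound 4 (0.92 log units; beyond the scatter), so compound 3 now stands apart from three analogs carrying a six-membered aromatic ring of carbon only, rather than two. Among those rings, chloro in place of methyl gives (a 1.5-fold higher number from compound 1 to compound 4 (0.18 log units; within the scatter)), so 4-chlorophenyl and 4-methylphenyl cannot be told apart at this position, while 4-chlorophenyl in place of 3-methoxyphenyl gives (a 2.4-fold higher number from compound 2 to compound 4 (0.38 log units; beyond the scatter)), the first step among these rings to lie beyond the scatter. Nothing in hand accounts for any of these steps.

Still open, on these data alone, is whether the lower number of compound 3 belongs to thiophen-2-yl alone or extends to other five-membered aromatic rings, such as furan-2-yl or thiazol-2-yl. Also open, as far as these compounds go, is how much of the gap between compound 2 and compound 4 comes from the group and how much from its place on the ring, a question that 3-chlorophenyl or 4-methoxyphenyl would address, and whether a saturated ring such as cyclohexyl or an amine such as morpholin-4-yl is tolerated here.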